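Swapping Acetyl for Tosyl on the Sugar Arm

The source may hold more compounds than are shown below. What is called first, only, known or untested is meant among the compounds shown, and "the series" means these compounds.

Measured so far:
compound 1, `O=[N+]([O-])c1ccc(-c2nc(CO[C@@H]3O[C@H](CO)[C@H]4OC5(CCCC5)O[C@@H]34)no2)cc1`, gives 41000 nM in a functional assay on WiDr cells (Homo sapiens) for antiproliferative activity, read by sulforhodamine B assay, with a stated time of 48 h; on this read-out lower numbers stand for stronger inhibition of growth and higher numbers for weaker inhibition of growth
compound 2, `CC(=O)OC[C@H]1O[C@@H](OCc2noc(-c3ccc([N+](=O)[O-])cc3)n2)[C@@H]2OC3(CCCC3)O[C@@H]21`, gives 36000 nM in this assay

Among the compounds with values here, compound 2 and compound 1 sit within the scatter of each other: the only step between them, a 1.1-fold lower number from compound 1 to compound 2 (0.06 log units; within the scatter), is too small to count as a real difference, so neither can be called the more or less active of the pair.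

The next compound, compound 3, `Cc1ccc(S(=O)(=O)OC[C@H]2O[C@@H](OCc3noc(-c4ccc([N+](=O)[O-])cc4)n3)[C@@H]3OC4(CCCC4)O[C@@H]32)cc1`, follows the same pattern of change at the same position. The difference from compound 2 reads ((4-methylphenyl)sulfonyl in place of acetyl on an oxygen on a saturated carbon). Within the data shown here, the one step that bears on this position is the change from hydrogen to acetyl, a 1.1-fold lower number from compound 1 to compound 2 (0.06 log units; within the scatter), which did nothing beyond the scatter. Among the measured compounds shown here, no measured step shows what a larger sulfonyl group on this oxygen does, so the expectation rests on that single small step.

Compound 3 is therefore expected to stay close to compound 2, with a step of a 1.2-fold lower number from compound 2 to compound 3 (0.08 log units; within the scatter), which is not expected to exceed the scatter. The estimate for compound 3 in this assay is 30000 nM, with a range from 10000 nM to 90000 nM.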

Compound 3, concentration for 50% growth inhibition: > 100000 nM
Compound 3: a limit, no number; the forecaster's own chance of this, stated with the estimate: 10%; at least 3.3-fold (0.52 log units) between middle value and limit.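

In this assay, the oxygen on a saturated carbon turns out not to be indifferent to what it carries: (4-methylphenyl)sulfonyl in place of acetyl gives an at least 2.7-fold higher number from compound 2 to compound 3 (0.44 log units; beyond the scatter), and the same group in place of hydrogen gives an at least 2.4-fold higher number from compound 1 to compound 3 (0.38 log units; beyond the scatter). Hydrogen and acetyl could not be told apart at this position, so this is the first change here that goes beyond the scatter, and it goes towards weaker inhibition of growth. Compound 3 is recorded as a limit and not as a number, which means that the true size of both steps stays unknown: the limit of > 100000 nM in this assay, at which 1 of the 3 values shown sits.

The change brings in a sulfonyl link, an aromatic ring of carbon only and a larger number of heavy atoms all at once, and these compounds cannot show which of these matters. A methanesulfonyl group on the same oxygen would keep the sulfonyl link without the ring, a benzoyl group would keep the ring without the sulfonyl link, and an amine at this place would test a different kind of group altogether.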